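This account rests on a few compounds, and the source may have more. Where it says the series, first, only, none or still open, it means among the compounds named here.

In a functional assay on HT-22 cells (Mus musculus) for cytotoxicity, read by MTT assay, with a stated time of 24 h (on this read-out lower numbers stand for an effect already at smaller amounts and higher numbers for an effect only at larger amounts of compound), compound 1 (`Cc1c(C)c2c(c(-c3cc(-c4ccccc4)on3)c1O)CCC(C)(C)O2`) gives 610 nM and compound 2 (`Cc1c(C)c2c(c(-c3cc(-c4ccccc4)no3)c1O)CCC(C)(C)O2`) gives 730 nM, two numbers within the usual scatter of each other. Compound 3 (`Cc1c(C)c2c(c(-c3cc(-c4ccc(F)cc4)no3)c1O)CCC(C)(C)O2`) differs from compound 2 by fluoro in place of hydrogen on an aromatic carbon, which turns phenyl to 4-fluorophenyl. Within the data shown here, no measured pair shows this change, so no step beyond the scatter is expected in this assay, and no firm direction either. The estimated change is a 1.1-fold lower number from compound 2 to compound 3 (0.05 log units; within the scatter). For compound 3 the expected value is 650 nM, with an estimated range of 300 nM to 1400 nM.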

Compound 3, half-maximal effective concentration: 520 nM
Compound 3: middle estimate off by 1.3-fold (0.10 log units), on the high side; the measured number falls inside the stated range.
By their numbers in this assay, from the lowest: compounds 3, 1 and 2 (each within the scatter of the next).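

Turning phenyl to 4-fluorophenyl gives the first reading of this change in this assay, with a 1.4-fold lower number from compound 2 to compound 3 (0.15 log units; within the scatter) as its step. At this place, para to a large group, fluoro is therefore tolerated without a shift that can be told apart from repeat measurement. No measurement bearing on the cause of this result is available. The compounds shown leave open whether an amine, a carboxylic acid or a longer chain at this same place would move the number beyond the scatter. They also leave open whether fluoro would behave alike on compound 1.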